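A few compounds are considered here, and "the series" means these few. Any claim that something is new, unique, unknown or untested is made for them only; others in the source may bear on it.

Compound 1 `CCOc1ccccc1N/N=C1\CCC(C)n2c1ncc(C(=O)O)c2=O` and compound 2 `Cc1ccccc1N/N=C1\CCC(C)n2c1ncc(C(=O)O)c2=O` share one core and differ at a single aromatic carbon. In a functional assay on the whole organism for inhibition, with Rattus norvegicus as the target (on this read-out higher numbers stand for an effect only at larger amounts of compound and lower numbers for an effect already at smaller amounts), compound 1 gives only a limit of the assay, > 1000 umol/kg. Compound 2 likewise gives only a limit in this assay, > 100 umol/kg. The step that the two limits leave unreadable from compound 1 to compound 2 thus stays unreadable, as the limit of > 100 umol/kg in this assay, at which 1 of the 2 values shown sits, and the limit of > 1000 umol/kg in this assay, at which 1 of the 2 values shown sits, show. Compound 3 `CC1CC/C(=N\Nc2ccccc2CCO)c2ncc(C(=O)O)c(=O)n21` differs from compound 2 by hydroxymethyl in place of hydrogen on a saturated chain carbon bound to an aromatic carbon. For the measured compounds named here, no measured step bears on this change, and both known values are limits. Compound 3 is therefore expected to give about 300 umol/kg (range 50 umol/kg to 3000 umol/kg) in this assay. The step that the limit leaves unreadable from compound 2 to compound 3 is expected to be small.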

Compound 3, dose for 50% inhibition: > 100 umol/kg
Compound 3: a limit, no number; the forecaster's own chance of this, stated with the estimate: 70%; the middle value is on the limit's open side.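

In this assay, for the compounds shown here, compound 1, compound 2 and compound 3 all give only limits, so no step among them can be read. The compounds shown leave open whether exchanging ethoxy, methyl and 2-hydroxyethyl changes the dose for inhibition at all.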